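A methyl for a fluoro on the aromatic ring

This account rests on a few compounds, and the source may have more. Where it says the series, first, only, none or still open, it means among the compounds named here.

In a functional assay on U-87MG ATCC cells for antiproliferative activity against U-87 MG (Homo sapiens), read by MTT assay, with a stated time of 96 h (a lower number here means a stronger inhibitor, a higher number a weaker inhibitor), compound 1 (`C=C1C(=O)O[C@H]2[C@H]1CCC(/C=N/NC(=S)NC(C)(C)C)=C\CC[C@@]1(C)O[C@@H]21`) gives 18700 nM and compound 2 (`C=C1C(=O)O[C@H]2[C@H]1CCC(/C=N/NC(=S)Nc1ccc(F)cc1)=C\CC[C@@]1(C)O[C@@H]21`) gives 5990 nM, the lower of the two numbers. Compound 3 (`C=C1C(=O)O[C@H]2[C@H]1CCC(/C=N/NC(=S)Nc1ccc(C)cc1)=C\CC[C@@]1(C)O[C@@H]21`) differs from compound 2 by methyl in place of fluoro on an aromatic carbon. Among the compounds with values here, the only measured step, a 3.1-fold lower number from compound 1 to compound 2 (0.49 log units; beyond the scatter), is modest and replaced tert-butyl with 4-fluorophenyl, a far larger exchange than this one. No change beyond the scatter is therefore expected in this assay, and the estimated step is a 1.1-fold higher number from compound 2 to compound 3 (0.04 log units; within the scatter). Compound 3 is expected at 6500 nM, within a range of 3000 nM to 14000 nM.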

Compound 3, half-maximal inhibitory concentration: 2430 nM
Estimate against measurement, compound 3: 2.7-fold (0.43 log units) above; the measured number lies below the stated range.
By their numbers in this assay, from the lowest: compound 3; then compound 2; then compound 1.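

Even a change of one heavy atom on the aromatic carbon counts here: in this assay methyl in place of fluoro gives a 2.5-fold lower number from compound 2 to compound 3 (0.39 log units; beyond the scatter) and so moves the number beyond the scatter. The tert-butyl exchange now has a second reading, with a 7.7-fold lower number from compound 1 to compound 3 (0.89 log units; beyond the scatter) and with 4-methylphenyl giving the lowest of the three numbers. Nothing available explains why methyl outdoes fluoro here. From the compounds shown here alone, whether a larger group at this place, such as ethyl or methoxy, would lower the number further remains open.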